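From 4-Nitrophenyl to 3-Nitrophenyl in a Cytotoxicity Test

This account rests on a few compounds, and the source may have more. Where it says the series, first, only, none or still open, it means among the compounds named here.

Compound 1 `COc1ccc(/C=N/NC(=O)COc2cccc3ccccc23)cc1O` gives 27.7 ug/mL in an ADME assay on HEL cells (Homo sapiens) for cytotoxicity; on this read-out higher numbers stand for lower toxicity in this test and lower numbers for higher toxicity in this test.
Compound 2 `C/C(=N\NC(=O)COc1cccc2ccccc12)c1ccc([N+](=O)[O-])cc1` gives > 100 ug/mL in this assay, which is a limit of the test rather than a number.

Among the compounds with values here, only these two compounds have been measured, and no pair among them differs in a single place, so no measured step can be followed. Compound 2 stands only at a limit: the test reports (the limit of > 100 ug/mL in this assay, at which 1 of the 2 values shown sits), and where its true value lies above that is not known.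

Compound 3 `C/C(=N\NC(=O)COc1cccc2ccccc12)c1cccc([N+](=O)[O-])c1` differs from compound 2 by 3-nitrophenyl in place of 4-nitrophenyl on a carbon with a double bond to nitrogen. The two compounds hold the same atoms joined differently, and the only starting point is a limit. A step of no more than the usual scatter is therefore expected, in no particular direction, and the step of a number no higher from compound 2 to compound 3 (the limit leaves the size open) is the estimate meant here. Compound 3 is expected near 100 ug/mL, with a range from 50 ug/mL to 200 ug/mL, and most likely it will again be reported only as a limit in this assay.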

Compound 3, half-maximal cytotoxic concentration: 10.5 ug/mL
The estimate for compound 3 lay 9.5-fold (0.98 log units) above the measured number; the measured number lies below the stated range.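

In this assay, putting 3-nitrophenyl in place of 4-nitrophenyl on a carbon with a double bond to nitrogen gives an at least 9.5-fold lower number from compound 2 to compound 3 (0.97 log units; beyond the scatter), so at this place the way the same atoms are joined matters, and the lower number stands for higher toxicity in this test. The two groups match in every feature counted, so those counts alone do not separate them. Compound 2 stands only at a limit, so the step gives a smallest size and not a true one: the limit of > 100 ug/mL in this assay, at which 1 of the 3 values shown sits.

The compounds shown do not tell why the joining of the nitro group changes the read-out. They also leave open what an amine or a carboxylic acid in place of the nitro group on this ring would give.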